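Carboxy for amino on the pendant phenyl of a urea

A few compounds are considered here, and "the series" means these few. Any claim that something is new, unique, unknown or untested is made for them only; others in the source may bear on it.

Compound 2 `CC(C)c1cccc(C(C)C)c1NC(=O)NCC1(c2cccc(N)c2)CCCC1` is one of two ureas sharing a core and measured in an assay on microsomes for inhibition of acyl-CoA:cholesterol acyltransferase (Oryctolagus cuniculus); a higher number here means a weaker inhibitor, a lower number a stronger inhibitor. In this assay compound 2 gives 21 nM, the higher of the two numbers, but the gap to compound 1 `Cc1ccccc1C1(CNC(=O)Nc2c(C(C)C)cccc2C(C)C)CCCC1`, which gives 17 nM, is a 1.2-fold higher number from compound 1 to compound 2 (0.09 log units; within the scatter), within the scatter. Within the data shown here, that single measured step, 2-methylphenyl to 3-aminophenyl on the saturated ring carbon, is the only comparison available, and it shows this assay tolerating a change of the pendant aryl group without a shift beyond noise.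

Compound 3 `CC(C)c1cccc(C(C)C)c1NC(=O)NCC1(c2cccc(C(=O)O)c2)CCCC1` carries a different change: carboxy in place of amino on an aromatic carbon. Among the measured compounds shown here, no measured step bears on this exchange; the step from compound 1 to compound 2 concerns the aryl group as a whole and says nothing about carboxy against amino on that ring. Given only that tolerance, a modest weakening at most seems the most likely outcome, with a wide range of uncertainty. Compound 3 is therefore expected to show a 3.8-fold higher number from compound 2 to compound 3 (0.58 log units; beyond the scatter) in this assay, giving an estimated 80 nM, with a range from 20 nM to 400 nM.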

Compound 3, half-maximal inhibitory concentration: 620 nM
Compound 3: middle estimate off by 7.8-fold (0.89 log units), on the low side; the whole stated range lies below it.
By their numbers in this assay, from the lowest: compounds 1 and 2 (each within the scatter of the next); then compound 3.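

In this assay, among these compounds, the earlier pair showed only that one exchange of the pendant aryl group stayed within the scatter, whereas carboxy in place of amino, on an aromatic carbon meta to a large group, gives a 30-fold higher number from compound 2 to compound 3 (1.47 log units; beyond the scatter) and is the first change here to move the number beyond it. This position therefore does not accept every substituent alike, and what separates the two results is the group that enters, not a change of the core. Set against the 2-methylphenyl group, the 3-carboxyphenyl group gives a 36-fold higher number from compound 1 to compound 3 (1.56 log units; beyond the scatter) as well, so the weakening stands against both earlier aryl groups, though nothing shown here accounts for its size.

The compounds shown leave open whether the weakening belongs to the free carboxylic acid itself or would persist with a methyl ester, a primary amide or a hydroxymethyl group in the same place. They also leave open whether a carboxy group on another carbon of that ring would give a step of this size.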